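Ring methylation on a low-toxicity series: working notes

The source may report more compounds than this note shows. Statements on the series, on what has been measured and on what is new or still open speak of the compounds shown alone.

Measured so far in an ADME assay on MT4 cells (Homo sapiens) for activation, read by MTT assay; on this read-out higher numbers stand for lower toxicity in this test and lower numbers for higher toxicity in this test:
Compound 1 `CCCSc1nc(Cc2c(F)cccc2Cl)cc(=O)[nH]1`; compound 1 gives > 80000 nM, a limit of the test.
Compound 2 `CCC(C)Sc1nc(Cc2c(F)cccc2Cl)cc(=O)[nH]1`; compound 2 gives > 76000 nM, a limit of the test.
Compound 3 `CCCCSc1nc(Cc2c(F)cccc2Cl)cc(=O)[nH]1`; compound 3 gives > 76000 nM, a limit of the test.

Compound 2 therefore stands only at a limit in this assay, and the two other values are limits as well. The steps a step that the two limits leave unreadable from compound 1 to compound 2, a step that the two limits leave unreadable from compound 1 to compound 3 and a step that the two limits leave unreadable from compound 2 to compound 3 cannot be sized, because the limit of > 76000 nM in this assay, at which 2 of the 3 values shown sit, and the limit of > 80000 nM in this assay, at which 1 of the 3 values shown sits, cap every value in the set.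

Compound 4 `CCC(C)Sc1nc(Cc2c(F)cccc2Cl)c(C)c(=O)[nH]1` differs from compound 2 by methyl in place of hydrogen on an aromatic carbon, placed on an aromatic carbon of a six-membered aromatic ring with 2 nitrogen, para to a (sec-butyl)sulfanyl group. Within the data shown here, no measured step touches this position, and no measured step is readable at all, so no direct precedent bears on the change. The step from compound 2 to compound 4 is expected to be a number no higher from compound 2 to compound 4 (the limit leaves the size open), that is nothing beyond the scatter, with another limit the most likely outcome. Compound 4 is estimated at 76000 nM, within 30000 nM to 160000 nM.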

Compound 4, half-maximal cytotoxic concentration: > 73000 nM
Compound 4 gave a limit, no number; the forecaster's own chance of this, stated with the estimate: 80%; the middle value is on the limit's open side.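

In this assay compound 4 gives > 73000 nM, a limit of the test. Compound 2 also stands at a limit, and no new step can be read between compound 2 and compound 4. The compounds shown leave open at what concentration any of them becomes toxic in this assay, and whether methyl in place of hydrogen on the aromatic carbon changes that concentration at all.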